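The source may report more compounds than this note shows. Statements on the series, on what has been measured and on what is new or still open speak of the compounds shown alone.

For the measured compounds named here, in a functional assay on CHO-K1 cells (Cricetulus griseus) for inhibition, read by MTT assay, with a stated time of 72 h (on this read-out lower numbers stand for stronger inhibition and higher numbers for weaker inhibition), only two compounds have been tested so far. Going by the values given here, compound 1 (`COc1cc(/C=C/C(=O)/C=C(/C=C/c2ccc(OC(C)=O)c(OC)c2)NC2CCCCC2)ccc1OC(C)=O`), which carries a cyclohexyl group on an amine nitrogen, gives 10100 nM, the only exact number in the set. For compound 2 (`CCCNC(=C\C(=O)/C=C/c1ccc(O)c(OC)c1)/C=C/c1ccc(O)c(OC)c1`) the result is a limit, > 25000 nM. Among the compounds with values here, these two compounds do not differ in just one place, so they provide no measured step that could serve as a guide.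

Attention now turns to compound 3 (`COc1cc(/C=C/C(=O)/C=C(/C=C/c2ccc(OC(C)=O)c(OC)c2)NCC(C)C)ccc1OC(C)=O`), which keeps the core of compound 1 and changes a single group. It has isobutyl in place of cyclohexyl on an amine nitrogen, and the counted difference reads (isobutyl in place of cyclohexyl on an amine nitrogen). The one six-membered non-aromatic ring of carbon only is lost, and the swap leaves no net charge.

With compound 1 at 10100 nM as the sole anchor, no shift beyond the usual scatter is expected in this assay. The estimated step of a 1.2-fold higher number from compound 1 to compound 3 (0.07 log units; within the scatter) is expected to be small, with no firm direction. For compound 3 the expected value is 12000 nM, within an estimated range of 5000 nM to 25000 nM.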

Compound 3, half-maximal inhibitory concentration: > 25000 nM
Compound 3: only a limit was reported; the forecaster's own chance of this, stated with the estimate: 15%; at least 2.0-fold (0.31 log units) between middle value and limit.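

In this assay, for the compounds shown here, the change from cyclohexyl to isobutyl on an amine nitrogen gives the first readable step in this set: an at least 2.4-fold higher number from compound 1 to compound 3 (0.39 log units; beyond the scatter). This shows that the read-out at this position depends on the group the nitrogen carries, and that the loss of cyclohexyl here is not a neutral swap. Compound 3 gives > 25000 nM, which is a limit and not a number, so the step has a lower bound but no measured size, and the comparison rests on this single pair: the limit of > 25000 nM in this assay, at which 2 of the 3 values shown sit.

The compounds shown do not separate the loss of the ring from the loss of carbon count, as isobutyl differs from cyclohexyl in both respects; a straight hexyl chain or a cyclobutyl group on the same nitrogen would pull these two apart. They also leave open whether a larger ring such as cycloheptyl, or an aromatic group such as benzyl, would give a lower number than compound 1 does on the same core.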